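The source may report more compounds than this note shows. Statements on the series, on what has been measured and on what is new or still open speak of the compounds shown alone.

Three compounds of the series have numbers in a functional assay on A549 cells (Homo sapiens) for cytotoxicity, read by sulforhodamine B assay, with a stated time of 48 h; on this read-out higher numbers stand for lower toxicity in this test and lower numbers for higher toxicity in this test. Compound 1 `ClCc1cccc(Cn2cnc3ncnc(Cl)c32)c1` gives 91200 nM, compound 2 `ClCc1cccc(Cn2cnc3c(Cl)ncnc32)c1` gives 79400 nM, and compound 3 `ClCc1ccc(Cn2cnc3c(Cl)nc(Cl)nc32)cc1` gives 74100 nM. The number of compound 2 lies between those of compound 1 and compound 3, and both gaps are within the scatter, so the three cannot be told apart on this read-out. Compound 4 `Nc1nc(Cl)c2ncn(Cc3cccc(CCl)c3)c2n1` has not been measured. It differs from compound 2 by amino in place of hydrogen on an aromatic carbon. Going by the values given here, no measured pair carries this change, so nothing here shows its effect on the concentration lethal to half the cells. The step is expected to stay within the scatter, with no direction preferred, estimated as a 1.0-fold higher number from compound 2 to compound 4 (0.00 log units; within the scatter). For compound 4 the expected number in this assay is 80000 nM, with a range from 35000 nM to 180000 nM.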

Compound 4, concentration lethal to 50% of the cells: 63100 nM
Beside the measured number, compound 4's estimate is 1.3-fold (0.10 log units) above it; the measured number falls inside the stated range.
By their numbers in this assay, from the lowest: compounds 4, 3, 2 and 1 (each within the scatter of the next).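

In this assay, amino in place of hydrogen on an aromatic carbon, between two ring nitrogen atoms, gives a 1.3-fold lower number from compound 2 to compound 4 (0.10 log units; within the scatter) and so shows no effect that can be told from the scatter. This position therefore carries the amino group with the read-out unchanged within the scatter, though that rests on a single pair. Nothing available bears on the reason for this result.

From the compounds shown here alone, whether a dimethylamino group, a hydroxyl or a longer chain on this carbon would behave the same remains open. Also open, going by these compounds, is what a methyl group in place of the chloromethyl group would do.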